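A few compounds are considered here, and "the series" means these few. Any claim that something is new, unique, unknown or untested is made for them only; others in the source may bear on it.

In a functional assay on NCI-H460 cells (Homo sapiens) for inhibition, read by sulforhodamine B assay, with a stated time of 48 h (a higher number here means that more compound is tolerated, a lower number that less compound is tolerated), the measured compounds stand as follows.

compound 1, `COc1cc(-c2nn(-c3cccc(NC(=O)Nc4cc(C(F)(F)F)cc(C(F)(F)F)c4)c3)cc2-c2ccncc2)ccc1Cl`: 16300 nM
compound 2, `O=C(Nc1cccc(-n2cc(-c3ccncc3)c(-c3ccc(Cl)c(O)c3)n2)c1)Nc1cc(C(F)(F)F)cc(C(F)(F)F)c1`: 4860 nM
compound 3, `COc1cc(-c2nn(-c3cccc(NC(=O)Nc4ccc(Cl)c(C(F)(F)F)c4)c3)cc2-c2ccncc2)ccc1Cl`: a limit only, > 32500 nM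

Compound 1 and compound 2 share the same core and differ in a single place: hydrogen in place of methyl on an oxygen on an aromatic ring. That single change produced a 3.4-fold lower number from compound 1 to compound 2 (0.53 log units; beyond the scatter), so within this pair the hydroxy compound is tolerated by the cells at a lower concentration than the methoxy compound.

Compound 3 carries a different urea partner from compound 1; the difference between the two cores is not broken down here. For compound 3 only a limit is known in this assay, namely (the limit of > 32500 nM in this assay, at which 1 of the 3 values shown sits), and no number stands behind it.

Compound 4, `O=C(Nc1cccc(-n2cc(-c3ccncc3)c(-c3ccc(Cl)c(O)c3)n2)c1)Nc1ccc(Cl)c(C(F)(F)F)c1`, has not yet been measured. It differs from compound 3 in one place: hydrogen in place of methyl on an oxygen on an aromatic ring. This is the same change that separates compound 1 from compound 2, and it sits in the same surroundings in both pairs. The expectation for compound 4 therefore rests on compound 1 and compound 2, whose step was a 3.4-fold lower number from compound 1 to compound 2 (0.53 log units; beyond the scatter), applied to the core of compound 3. The same change is expected to give an at least 1.3-fold lower number from compound 3 to compound 4 (0.11 log units; that floor lies within the scatter). Because compound 3 is known only as a limit, the starting point is not fixed, and the estimate for compound 4 is wide. Compound 4 is expected near 25000 nM, somewhere between 8000 nM and 70000 nM, and it may itself return only a limit.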

Compound 4, concentration lethal to 50% of the cells: > 32500 nM
Compound 4 was reported as a limit (the forecaster's own chance of this, stated with the estimate: 40%); middle value at least 1.3-fold (0.11 log units) away from the limit.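

In this assay, compound 3 and compound 4 both rest at a limit rather than a number, so no step between them can be read: the limit of > 32500 nM in this assay, at which 2 of the 4 values shown sit.

Going by these compounds, it remains open whether the methoxy to hydroxy change alters the number on the core of compound 3 as it does between compound 1 and compound 2.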